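Swapping Cyano for Chloro on an Inactive Urea

The compounds below may be only part of what the source reports. "The series", "measured", "known", "first", "only" and "open" are said of these compounds alone.

Compound 1, `O=C(NCc1ccccc1)N(Cc1ccccn1)n1cnnc1`: > 50000 nM
Compound 2, `Cc1ccsc1CN(C(=O)Nc1cccc(C#N)c1)n1cnnc1`: > 50000 nM

Of the compounds shown here, two have been tested in a functional assay on MDA-MB-231 cells (Homo sapiens) for cytotoxicity, read by MTT assay, with a stated time of 48 h (a lower number here means a stronger inhibitor, a higher number a weaker inhibitor), so far, and neither gave a number. Compound 1 shows only the limit > 50000 nM, which is not a measured value. Compound 2 likewise shows only the limit > 50000 nM in this assay. Going by the values given here, that leaves compound 2 at the bottom of what the numbers tell: both values sit at the limit of > 50000 nM in this assay, at which 2 of the 2 values shown sit, so no step between measured compounds can be read at all.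

Compound 3, `Cc1ccsc1CN(C(=O)Nc1cccc(Cl)c1)n1cnnc1`, keeps the whole core of compound 2 and changes one group: chloro in place of cyano on an aromatic carbon, read one bond further out as 3-cyanophenyl to 3-chlorophenyl. Among the compounds with values here, no measured step guides this change, so the step from compound 2 to compound 3 in this assay is expected to be none beyond the scatter, the estimated shift being a step that the limit leaves unreadable from compound 2 to compound 3. Compound 3 is therefore expected to sit near 60000 nM, in the range 20000 nM to 200000 nM, most likely again reported only as a limit.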

Compound 3, half-maximal inhibitory concentration: 40300 nM
The estimate for compound 3 lay 1.5-fold (0.17 log units) above the measured number, and the stated range covers the measured number.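

In this assay, going by these compounds alone, compound 3 gives 40300 nM, the first actual number, so chloro at this place on the aromatic ring brings the compound within the range the assay can read. The change amounts to an at least 1.2-fold lower number from compound 2 to compound 3 (0.09 log units; that floor lies within the scatter), so only a floor on the change is known, and that floor alone does not establish a real gain. The true size of the step stays hidden, since its starting point is a limit and not a number: the limit of > 50000 nM in this assay, at which 2 of the 3 values shown sit.

The compounds shown leave open whether another group at this place, such as an amine, a methoxy or a carboxylic acid, would lower the number further. They also leave open whether chloro elsewhere on the same ring would give a similar value.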